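Removing both hydroxy groups from a chalcone hemolysis inhibitor

This account rests on a few compounds, and the source may have more. Where it says the series, first, only, none or still open, it means among the compounds named here.

Measured compounds:
compound 1, `COc1cc(OC)c(-c2cc(=O)c3cc(O)ccc3o2)cc1OC`: 2.14 ug/mL
compound 2, `COc1cc(OC)c(OC)cc1/C=C/C(=O)c1ccc(O)cc1O`: 2.37 ug/mL
compound 3, `COc1cc(OC)c(-c2cc(=O)c3cc(Cl)ccc3o2)cc1OC`: 2.13 ug/mL

In a functional assay on cells (Erythrocyte, Rattus norvegicus) for inhibition, read by hemolysis, with a stated time of 1 h (on this read-out lower numbers stand for stronger inhibition and higher numbers for weaker inhibition), compound 2 gives the highest of the three numbers, yet its neighbours sit close: compound 1 gives 2.14 ug/mL and compound 3 gives 2.13 ug/mL, both within the scatter of compound 2, so no order among the three can be claimed.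

Compound 4, `COc1cc(OC)c(OC)cc1/C=C/C(=O)c1ccccc1`, has not yet been measured. It differs from compound 2 in one place: phenyl in place of 2,4-dihydroxyphenyl on a carbonyl carbon

Within the data shown here, only one measured step bears on this, and only loosely. From compound 1 to compound 3 a hydroxy on an aromatic carbon was exchanged for chloro, and a 1.0-fold lower number from compound 1 to compound 3 (0.00 log units; within the scatter). That step sits on a different core and touches a single hydroxy, whereas compound 4 loses two; still, it is the one indication that a hydroxy on the ring carried by this assay is not decisive. Compound 4 is therefore expected to show a 1.4-fold higher number from compound 2 to compound 4 (0.13 log units; within the scatter), a small rise in number at most. The estimate for compound 4 in this assay is 3.2 ug/mL, with a range from 1.3 ug/mL to 8 ug/mL.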

Compound 4, half-maximal inhibitory concentration: 2.23 ug/mL
Beside the measured number, compound 4's estimate is 1.4-fold (0.16 log units) above it; measured number inside the range.
By their numbers in this assay, from the lowest: compounds 3, 1, 4 and 2 (each within the scatter of the next).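

In this assay, the step from the 2,4-dihydroxyphenyl to phenyl on the carbonyl carbon gives a 1.1-fold lower number from compound 2 to compound 4 (0.03 log units; within the scatter), so the hydroxy groups of this ring can go together without a change that can be read. The earlier step touched a single hydroxy on another core, whereas this one takes the group on the core of compound 2 from 2 hydrogen-bond donors to 0, and the result is still flat. Nothing available offers a cause for this flat result.

What the compounds shown leave open is whether any group at this place moves the number in this assay beyond the scatter. An amine or a carboxylic acid on the phenyl, or a longer chain in place of the ring, could test that.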